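Shortening the chain on the methyl cyanoguanidine analogue

This account rests on a few compounds, and the source may have more. Where it says the series, first, only, none or still open, it means among the compounds named here.

Measured so far in a functional assay on the whole organism (stomach) with Rattus norvegicus as the target; on this read-out lower numbers stand for an effect already at smaller amounts and higher numbers for an effect only at larger amounts of compound:
compound 1 `C/N=C(/NC#N)NCCCCCn1nc(-c2ccccc2)ccc1=O` 100 mg/kg
compound 2 `CC/N=C(/NC#N)NCCCCn1nc(-c2ccccc2)cc(C)c1=O` 100 mg/kg
compound 3 `C/N=C(/NC#N)NCCCCCn1nc(-c2ccccc2)cc(C)c1=O` > 100 mg/kg

Compound 3 gives only a limit, (the limit of > 100 mg/kg in this assay, at which 1 of the 3 values shown sits), so no number is known for it. Both routes into it, a number no lower from compound 1 to compound 3 (the limit leaves the size open) and a number no lower from compound 2 to compound 3 (the limit leaves the size open), leave the step size open. Compound 4 `C/N=C(/NC#N)NCCCCn1nc(-c2ccccc2)cc(C)c1=O` differs from compound 3 by a group of 7 heavy atoms (3 carbon, 4 nitrogen; no ring) in place of a group of 8 heavy atoms (4 carbon, 4 nitrogen; no ring), on a saturated chain carbon, four bonds along the chain from an aromatic nitrogen. This change goes back toward compound 2, which differs from compound 4 only in the group on the chain carbon; compound 2 gives 100 mg/kg in this assay. Among the measured compounds shown here, no step with a readable size bears on this change. Compound 4 is therefore expected to sit near compound 2, at an estimated 100 mg/kg (range 50 mg/kg to 200 mg/kg), meaning an expected step of a number no higher from compound 3 to compound 4 (the limit leaves the size open) that may again end in a limit.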

Compound 4, dose for half-maximal effect: 60.8 mg/kg
Compound 4: the middle estimate sits 1.6-fold (0.22 log units) above what was measured; the range from low to high includes it.
By their numbers in this assay, from the lowest: compounds 4, 1 and 2 (each within the scatter of the next).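

The group with 7 heavy atoms in place of the group with 8 heavy atoms, on a saturated chain carbon, four bonds along the chain from an aromatic nitrogen, gives an at least 1.6-fold lower number from compound 3 to compound 4 (0.21 log units; that floor lies within the scatter), so this position now yields a number on at least one side of the change. The other side remains a limit, so the full size stays unknown: the limit of > 100 mg/kg in this assay, at which 1 of the 4 values shown sits.
Hydrogen in place of methyl on a saturated chain carbon bound to a double-bonded nitrogen gives a 1.6-fold lower number from compound 2 to compound 4 (0.22 log units; within the scatter), so this assay does not separate these two end groups.

As far as these compounds go, whether the change at the chain carbon reaches beyond the scatter stays open. So does whether a propyl group in place of that methyl, or a longer chain, would shift the number.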